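The source may hold more compounds than are shown below. What is called first, only, known or untested is meant among the compounds shown, and "the series" means these compounds.

Of the compounds shown here, three have so far been tested in a functional assay on KG-1 cells (Homo sapiens) for cytotoxicity, read by luminescence and CellTiter-Glo, with a stated time of 3 days; a lower number here means a stronger inhibitor, a higher number a weaker inhibitor. Compound 1 `O=C(Nc1ccc(C(F)(F)F)cc1)c1cc(Cl)ccc1O` gives 740 nM. Compound 2 `N#Cc1ccc(NC(=O)c2ccc(Cl)cc2O)cc1` gives 1920 nM, and compound 3 `N#Cc1ccc(NC(=O)c2cc(Cl)ccc2O)cc1` gives 1860 nM. Compound 2 and compound 3 are built from the same atoms joined differently; the difference between the two cores is not broken down here, and their two values lie within the usual scatter of each other. Compound 1 differs from compound 3 in one place, (trifluoromethyl in place of cyano on an aromatic carbon), and this gave a 2.5-fold lower number from compound 3 to compound 1 (0.40 log units; beyond the scatter).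

Compound 4 `O=C(Nc1ccc(C(F)(F)F)cc1)c1ccc(Cl)cc1O` has not yet been measured. It differs from compound 2 by the same change, (trifluoromethyl in place of cyano on an aromatic carbon), at a place described in the same words as in the measured pair, so the change counts as the same. Among the measured compounds shown here, the only measured example of it is the step of a 2.5-fold lower number from compound 3 to compound 1 (0.40 log units; beyond the scatter), so the same kind of step is expected here. The step of a 2.5-fold lower number from compound 2 to compound 4 (0.39 log units; beyond the scatter) is the estimate that follows from applying the measured step of a 2.5-fold lower number from compound 3 to compound 1 (0.40 log units; beyond the scatter) to compound 2. Compound 4 is therefore expected to give about 780 nM in this assay, most likely between 380 nM and 1600 nM.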

Compound 4, half-maximal inhibitory concentration: 580 nM
Compound 4: the middle estimate sits 1.3-fold (0.13 log units) above what was measured; the range from low to high includes it.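

In this assay, putting trifluoromethyl in place of cyano gave a 3.3-fold lower number from compound 2 to compound 4 (0.52 log units; beyond the scatter), so the change has now been seen on two cores, and in both cases the number fell by more than the scatter. Set beside the earlier step, the size of the change carried over from one core to the other: the same change on two cores in this assay, a 2.5-fold lower number (0.40 log units; beyond the scatter) from compound 3 to compound 1 and a 3.3-fold lower number (0.52 log units; beyond the scatter) from compound 2 to compound 4, 1.3-fold (0.12 log units) apart, within the scatter of two such steps. Among the compounds shown here, this rests on only two pairs, whose cores are built from the same atoms joined differently, so it does not show that the step would hold on a core that differs more, and it does not explain why the number falls.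

On these data alone, only cyano and trifluoromethyl appear at this place, so it remains open how an amine, a carboxylic acid or a longer chain would behave there. All four compounds were also compared only in this assay, which leaves open whether the same step would appear in any other test.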